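Bromo to Nitrooxy on the Acyl Side Chain

The compounds below may be only part of what the source reports. "The series", "measured", "known", "first", "only" and "open" are said of these compounds alone.

Measured so far:
Compound 1, `COc1ccc(C2=NNC(c3ccco3)C2)cc1OC`: 53%
Compound 2, `COc1ccc(C2=NN(C(=O)C(C)Br)C(c3ccco3)C2)cc1OC`: 36%

In a functional assay on the whole organism (strain albino) for inhibition, with Rattus norvegicus as the target, read by paw edema, with stated times of 30 min and 2 h, at a dose of 100 mg/kg by the oral route (on this read-out higher numbers stand for more inhibition at the one dose given (going by the name of the read-out) and lower numbers for less inhibition), compound 2 stands lowest of the two numbers; its nearest neighbour, compound 1, sits higher by the step of a number 17 percentage points lower from compound 1 to compound 2 (beyond the scatter). Compound 3, `COc1ccc(C2=NN(C(=O)C(C)O[N+](=O)[O-])C(c3ccco3)C2)cc1OC`, has not yet been measured. It differs from compound 2 by nitrooxy in place of bromo on a saturated chain carbon bound to a carbonyl carbon and a saturated chain carbon. Within the data shown here, the only measured step, a number 17 percentage points lower from compound 1 to compound 2 (beyond the scatter), concerns a (1-bromoethyl)carbonyl group entering on the ring nitrogen and says nothing about exchanging the bromo for a nitrooxy group; no measured pair bears directly on this change. With no guidance on the swap itself, the expected step of a number 4 percentage points higher from compound 2 to compound 3 (within the scatter) is small and may well stay within the scatter. Compound 3 is therefore estimated at 40%, with a range from 25% to 55%.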

Compound 3, a percentage reported as inhibition, in the whole organism at one dose (the size of the read-out at that dose, not a potency): 39%
Estimate against measurement, compound 3: 1 percentage points above; the range from low to high includes it.
By their numbers in this assay, from the lowest: compounds 2 and 3 (each within the scatter of the next); then compound 1.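

In this assay, putting nitrooxy in place of bromo on this saturated chain carbon gives a number 3 percentage points higher from compound 2 to compound 3 (within the scatter), so these two groups cannot be told apart here, although nitrooxy is the larger group by heavy-atom count. The nitrooxy side chain on the amine nitrogen in a ring also gives a number 14 percentage points lower from compound 1 to compound 3 (beyond the scatter), so both substituted compounds, compound 2 and compound 3, read below the unsubstituted compound 1, whichever of the two groups the chain carries. Nothing available explains either result.

The compounds shown leave open whether this shortfall comes with the carbonyl side chain as a whole or depends on the group on its chain carbon. A plain acetyl group, or an amine or a hydroxyl group in place of the nitrooxy, would help separate these, as would a longer chain.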